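Swapping the Side Group on the Shared Core

This account rests on a few compounds, and the source may have more. Where it says the series, first, only, none or still open, it means among the compounds named here.

Measured compounds:
compound 1 `CCC1CCCCN1C(=O)n1cc(-c2ccc(-c3ccccc3)cc2)nn1` — 20 nM
compound 2 `COc1ccc(CC2CCCCN2C(=O)n2ncc(C(O)(c3ccc(F)cc3)c3ccc(F)cc3)n2)cc1` — 5.01 nM
compound 3 `O=C(N1CCCCC1COc1ccccc1)n1ncc(C(O)(c2ccccc2)c2ccccc2)n1` — 7.94 nM

Three compounds were tested in an assay on HEK-293T cells for inhibition of diacylglycerol lipase-alpha (Homo sapiens), read by colorimetric assay; a higher number here means a weaker inhibitor, a lower number a stronger inhibitor. Compound 2 gives the lowest number of the three, 5.01 nM. The value of compound 3, 7.94 nM, lies within the usual scatter of that number, so the two cannot be set in order. Compound 1, with 20 nM, stands beyond the scatter above compound 2.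

Compound 4 `O=C(N1CCCCC1COc1ccccc1)n1ncc(C(O)(c2ccc(F)cc2)c2ccc(F)cc2)n1` has not yet been measured in this assay. It differs from compound 2 in one place:

phenoxy in place of 4-methoxyphenyl on a saturated chain carbon bound to a saturated ring carbon

For the measured compounds named here, no step between two measured compounds isolates this exact change, so there is no directly comparable pair. Compound 3, which already carries phenoxy on the saturated chain carbon, sits within the scatter of compound 2, which argues for a small step. The step from compound 2 to compound 4 is expected to be a 1.0-fold lower number from compound 2 to compound 4 (0.00 log units; within the scatter), that is, no change beyond the scatter. Compound 4 is therefore estimated at 5 nM, with a range from 2 nM to 15 nM.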

Compound 4, half-maximal inhibitory concentration: 5.01 nM
Estimate against measurement, compound 4: 1.0-fold (0.00 log units) below, and the stated range covers the measured number.
By their numbers in this assay, from the lowest: compounds 2, 4 and 3 (each within the scatter of the next); then compound 1.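

In this assay, for the compounds shown here, the exchange of 4-methoxyphenyl for phenoxy on a saturated chain carbon bound to a saturated ring carbon gives no change at the digits printed from compound 2 to compound 4 (within the scatter) and is the first reading of this change with the rest of the molecule held constant. The earlier compounds shown here differed from one another in more than one place, so they could not isolate it, whereas here the 4-methoxybenzyl and phenoxymethyl side groups cannot be told apart at this position. No measurement shown accounts for this result.

The compounds shown leave open how this position responds to a group of another kind, such as an amine, a carboxylic acid or a longer chain. They also leave open whether the same exchange would read alike on the core of compound 1.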